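Lengthening the acyl chain on a leukotriene receptor ligand

The compounds below may be only part of what the source reports. "The series", "measured", "known", "first", "only" and "open" are said of these compounds alone.

compound 1 `C=CCc1cc(C(C)=O)c(O)cc1OCCCCC#N`: 57%
compound 2 `C=CCc1ccc(O)cc1OCCCCC#N`: 9%
compound 3 `C=CCc1cc(C(=O)CC)c(O)cc1OCCCCC#N`: 36%

In an assay on isolated protein for binding affinity to leukotriene B4 receptor 1 (Homo sapiens), tested at 1 uM (a lower number here means less inhibition, a higher number more inhibition at the concentration tested (going by the name of the read-out)), compound 1 gives 57%, the highest of the three numbers. Compound 3 stands second highest: compared with compound 1 the change is a number 21 percentage points lower from compound 1 to compound 3 (beyond the scatter), and compared with compound 2 it is a number 27 percentage points higher from compound 2 to compound 3 (beyond the scatter). Removing the acyl group altogether gives the largest step seen here, a number 48 percentage points lower from compound 1 to compound 2 (beyond the scatter).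

Compound 4 `C=CCc1cc(C(=O)CCCCCCCCC)c(O)cc1OCCCCC#N` differs from compound 3 in one place: heptyl in place of hydrogen on a saturated chain carbon, two bonds along the chain from a carbonyl carbon. Going by the values given here, the step that bears most directly on this change is the one from compound 1 to compound 3, where one added carbon on the chain bound to the carbonyl gave a number 21 percentage points lower from compound 1 to compound 3 (beyond the scatter). The steps to compound 2 show that the acyl group carries much of the measured inhibition, so the direction of a much longer chain is not settled by the three numbers. Extending the chain once lowered the number; a further, larger extension is therefore expected to lower it again, and for compound 4 the step of a number 10 percentage points lower from compound 3 to compound 4 (within the scatter) is expected, with a wide range. Compound 4 is estimated at 26%, between 5% and 58%.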

Compound 4, a percentage reported as inhibition, at one concentration (the size of the read-out at that concentration, not a potency): 7%
Beside the measured number, compound 4's estimate is 19 percentage points above it, within the range that was stated.
By their numbers in this assay, from the lowest: compounds 4 and 2 (each within the scatter of the next); then compound 3; then compound 1.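

The heptyl extension, placed on a saturated chain carbon, two bonds along the chain from a carbonyl carbon, gives a number 29 percentage points lower from compound 3 to compound 4 (beyond the scatter) in this assay, and the whole change from the acetyl group gives a number 50 percentage points lower from compound 1 to compound 4 (beyond the scatter), so the fall first seen with one added carbon continues across compounds 1, 3 and 4, and none of these three goes against it. Lengthening the chain this far leaves no measured advantage over having no acyl group at all: compound 4 gives 7% and compound 2 gives 9%, two values within the scatter of each other, so an acyl group at this position supports inhibition only when its chain is short. Nothing available here accounts for this loss with chain length.

The compounds shown do not tell whether the number falls steadily or drops at some particular length, since no acyl chain longer than that of compound 3 and shorter than that of compound 4 appears among them. Also open, going by these compounds, is whether a long chain ending in a carboxylic acid or an amine, or a formyl group in place of the acetyl, would keep or raise the inhibition.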